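A few compounds are considered here, and "the series" means these few. Any claim that something is new, unique, unknown or untested is made for them only; others in the source may bear on it.

Measured in an assay on SH-EP1 cells for displacement of a labelled ligand from Neuronal acetylcholine receptor; alpha4/beta2 (Homo sapiens), read by scintillation counting; on this read-out higher numbers stand for weaker inhibition and lower numbers for stronger inhibition:
compound 1 `O=C(C1CC1)N1CC2CC1CN2`, 2800 nM
compound 2 `CC(=O)N1CC2CC(C1)N2`, 150 nM
compound 3 `CCC(=O)N1CC2CC(C1)N2`, 6 nM

Compound 3 gives the lowest number of the three. Compound 2 is the nearest, separated by a 25-fold lower number from compound 2 to compound 3 (1.40 log units; beyond the scatter); compound 1, with a different core and a cyclopropyl carbonyl, lies furthest up. Compound 4 `CCCC(=O)N1CC2CC(C1)N2` carries the next extension of the chain: methyl in place of hydrogen on a saturated chain carbon, two bonds along the chain from a carbonyl carbon. Among the measured compounds shown here, the only step that bears on it is a 25-fold lower number from compound 2 to compound 3 (1.40 log units; beyond the scatter), the same kind of change one bond nearer the carbonyl carbon, and it was large. Whether a second such addition continues that trend is not shown by any pair here, so for compound 4 a step of about a 1.7-fold higher number from compound 3 to compound 4 (0.22 log units; within the scatter) in this assay is expected, with no clear direction. The estimate for compound 4 is 10 nM, in the range 3 nM to 40 nM.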

Compound 4, inhibition constant: 14 nM
Compound 4: the middle estimate sits 1.4-fold (0.15 log units) below what was measured, and the stated range covers the measured number.
By their numbers in this assay, from the lowest: compound 3; then compound 4; then compound 2; then compound 1.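

Extending ethyl to propyl no longer lowers the number (a 2.3-fold higher number from compound 3 to compound 4 (0.37 log units; beyond the scatter)), so the large drop seen on the first chain extension does not continue. Methyl in place of hydrogen thus reads differently two bonds along the chain from a carbonyl carbon, although compound 4 keeps most of the earlier gain (an 11-fold lower number from compound 2 to compound 4 (1.03 log units; beyond the scatter)). Nothing measured here accounts for this turn.

On these data alone, whether a longer chain such as butyl raises the number further, or a branched isopropyl on the shared core holds it low, stays open. Compound 1 differs from the others in both core and acyl group, so its cyclopropyl carbonyl cannot be read on its own.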